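The source may hold more compounds than are shown below. What is called first, only, known or untested is meant among the compounds shown, and "the series" means these compounds.

Compound 1 `N#Cc1cnc(NCc2cnccc2C(F)(F)F)cc1N[C@H]1C[C@H](O)C1`: 82%. Compound 2 `N#Cc1cnc(NCc2cnccc2C(F)(F)F)cc1NC[C@H]1C[C@H](O)C1`: 61%.

In an ADME assay on S9 fraction from liver (Rattus norvegicus) for metabolic stability, with a stated time of 1 h (on this read-out higher numbers stand for a more stable compound and lower numbers for a less stable compound), compound 1 holds the higher of these two numbers. Compound 3 `N#Cc1cnc(NCc2cnccc2C(F)(F)F)cc1N[C@H]1CC[C@@H](C(N)=O)CC1` differs from compound 1 by 4-carbamoylcyclohexyl in place of 3-hydroxycyclobutyl on a nitrogen on an aromatic ring. Going by the values given here, no measured pair shares this exact change; the only step available, a number 21 percentage points lower from compound 1 to compound 2 (beyond the scatter), reworks the group on the same nitrogen and shows that such an alteration can cost stability, so a modest fall in this assay is expected, a number 17 percentage points lower from compound 1 to compound 3 (beyond the scatter), with wide uncertainty. Compound 3 is therefore estimated at 65%, between 40% and 85%.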

Compound 3, percent of the compound remaining: 30%
Beside the measured number, compound 3's estimate is 35 percentage points above it; measured number below the stated range.
By their numbers in this assay, from the lowest: compound 3; then compound 2; then compound 1.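

In this assay, the group on this nitrogen on an aromatic ring can cost far more stability than the earlier pair showed: 4-carbamoylcyclohexyl gives a number 52 percentage points lower from compound 1 to compound 3 (beyond the scatter) and a number 31 percentage points lower from compound 2 to compound 3 (beyond the scatter). Both steps are large and beyond the usual scatter, which places compound 3 lowest of the three. Nothing measured here explains this fall.

The change to compound 3 alters both ring size and the ring's substituent, so the compounds shown leave open which of the two matters. A 4-hydroxycyclohexyl or a 3-carbamoylcyclobutyl group on the same nitrogen would separate them.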